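The compounds below may be only part of what the source reports. "The series", "measured", "known", "first", "only" and "open" are said of these compounds alone.

Measured so far:

Compound 1, `Cc1ncc(Cc2nc(-c3nc(C(F)(F)F)n[nH]3)n3cccc(F)c23)cn1`, gives 2.
Compound 2, `Fc1ccccc1Cc1nc(-c2ncn[nH]2)n2ccccc12`, gives 3.3.
Compound 3, `FC(F)(F)c1n[nH]c(-c2nc(Cc3cncnc3)c3ccccn23)n1`, gives 1.8.

These three numbers come from a physicochemical assay for lipophilicity, measured as octanol-water partition, at pH 7.4; on this read-out higher numbers stand for higher lipophilicity and lower numbers for lower lipophilicity. Among them compound 2 has the highest value. Its nearest neighbour is compound 1, which lies beyond the usual scatter below it, and compound 3 lies further below still, also beyond the scatter. So compound 2 is clearly the most lipophilic of the three measured compounds.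

The next compound, compound 4, `CS(=O)(=O)c1n[nH]c(-c2nc(Cc3ccccc3F)c3ccccn23)n1`, is built from compound 2 by a single change:

methylsulfonyl in place of hydrogen on an aromatic carbon

Going by the values given here, no step between two measured compounds describes this change, so its size has to be judged from the change itself. A methylsulfonyl group, with its two oxygen atoms and two hydrogen-bond acceptors, entering in place of a hydrogen atom is expected to lower the number in this assay by a clear margin, beyond the scatter. The step from compound 2 to compound 4 is expected to be about a number 1.30 log units lower from compound 2 to compound 4 (beyond the scatter). Compound 4 is therefore estimated at 2, with a range from 1.3 to 2.7.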

Compound 4, distribution coefficient: 1.2
Beside the measured number, compound 4's estimate is 0.80 log units above it; the whole stated range lies above it.
By their numbers in this assay, from the lowest: compound 4; then compounds 3 and 1 (each within the scatter of the next); then compound 2.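

Putting methylsulfonyl in place of hydrogen on an aromatic carbon of the five-membered aromatic ring with 3 nitrogen gives, in this assay, a number a number 2.10 log units lower from compound 2 to compound 4 (beyond the scatter), a large step. Going by these compounds alone, this is the first comparison here between two compounds that differ in one place, so it shows that the number can move a long way through a change at this carbon alone, which lies between two ring nitrogen atoms. Nothing given here accounts for the size of this step.

Trifluoromethyl also stands on this ring in compound 1 and compound 3, but both differ from compound 2 in more than one place, so they cannot show its own step. As far as these compounds go, how a methyl group, an amine or a carboxylic acid would move the number at this carbon remains open.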